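Notes on the sulfur side chain, compound 2 to compound 3

The source may hold more compounds than are shown below. What is called first, only, known or untested is meant among the compounds shown, and "the series" means these compounds.

Among the measured compounds shown here, in a functional assay on PC-3 cells (Homo sapiens) for inhibition, read by MTT assay, with a stated time of 48 h (a lower number here means a stronger inhibitor, a higher number a weaker inhibitor), compound 2 `COc1cc(-c2nnc(SCc3ccc(F)cc3)n2-c2ccc(N(C)C)cc2)cc(OC)c1OC` gives 46500 nM, the only true number so far. Compound 1 `COc1cc(-c2nnc(SC)n2-c2ccc(N(C)C)cc2)cc(OC)c1OC` gives > 60000 nM, which is a limit of the assay and not a number. For the measured compounds named here, the single measured step is an at least 1.2-fold lower number from compound 1 to compound 2 (0.11 log units; that floor lies within the scatter). Going by the values given here, it shows no firm gain from adding the 4-fluorophenyl group, and it is the only step that touches this chain.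

Compound 3 `COc1ccc(C(=O)CSc2nnc(-c3cc(OC)c(OC)c(OC)c3)n2-c2ccc(N(C)C)cc2)cc1` carries the change ((4-methoxyphenyl)carbonyl in place of 4-fluorophenyl on a saturated chain carbon bound to a sulfur), that is, (4-methoxyphenyl)carbonyl in place of 4-fluorophenyl on a saturated chain carbon bound to a sulfur. Among the compounds with values here, no measured step covers this exchange, so the expectation rests on compound 2 at 46500 nM and on the small size of an at least 1.2-fold lower number from compound 1 to compound 2 (0.11 log units; that floor lies within the scatter). The expected step is a 1.1-fold lower number from compound 2 to compound 3 (0.04 log units; within the scatter), with no shift beyond the scatter anticipated. Compound 3 is estimated at 42000 nM, with an expected range of 17000 nM to 60000 nM.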

Compound 3, half-maximal inhibitory concentration: 22000 nM
For compound 3 the middle estimate is 1.9-fold (0.28 log units) above the measured one, and the stated range covers the measured number.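

In this assay, among the compounds shown here, the exchange of 4-fluorophenyl for (4-methoxyphenyl)carbonyl on a saturated chain carbon bound to a sulfur gives the first step at this position that lies beyond the scatter (a 2.1-fold lower number from compound 2 to compound 3 (0.33 log units; beyond the scatter)), so the group carried there can move the number. Measured against hydrogen at the same place, the new group also clears the scatter (an at least 2.7-fold lower number from compound 1 to compound 3 (0.43 log units; beyond the scatter)), which the floor of the 4-fluorophenyl step did not. Compound 1 stands at a limit of the assay and not a number, so this second step is only a floor: (the limit of > 60000 nM in this assay, at which 1 of the 3 values shown sits).

The exchange changes the carbonyl and the ring substituent together, so the compounds shown do not tell which of the two carries the step. Going by these compounds, how an amine or a carboxylic acid on this chain carbon would read in this assay remains open.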